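Changing the Aryl Group on the Shared Core

The source may report more compounds than this note shows. Statements on the series, on what has been measured and on what is new or still open speak of the compounds shown alone.

Compound 1 `Cc1ccc(-n2nnc(C(=O)Nc3ccc(SC#N)cc3)c2C)cc1C`: in a functional assay on HEK293 cells (Homo sapiens) for antiproliferative activity, read by MTT assay, with a stated time of 72 h (a lower number here means a stronger inhibitor of growth, a higher number a weaker inhibitor of growth), compound 1 gives > 100000 nM, which is a limit of the assay and not a number.
Compound 2 `Cc1ccc(Cl)c(-n2nnc(C(=O)Nc3ccc(SC#N)cc3)c2C)c1`: in this assay compound 2 gives > 100000 nM, also a limit.

Compound 1 therefore stands only at a limit, and both values shown sit at the limit of > 100000 nM in this assay, at which 2 of the 2 values shown sit. Going by the values given here, the one measured step, a step that the two limits leave unreadable from compound 1 to compound 2, cannot be read because both ends are limits.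

Compound 3 `COc1cccc(-n2nnc(C(=O)Nc3ccc(SC#N)cc3)c2C)c1` differs from compound 1 by 3-methoxyphenyl in place of 3,4-dimethylphenyl on an aromatic nitrogen. Among the compounds with values here, no measured step bears readably on this change, so there is nothing to suggest a step beyond the scatter in either direction; the likeliest outcome is that compound 3 also reaches only the limit. I expect the step from compound 1 to compound 3 to be about a number no higher from compound 1 to compound 3 (the limit leaves the size open). My estimate for compound 3 is 100000 nM, in a range from 30000 nM to 300000 nM.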

Compound 3, concentration for 50% growth inhibition: > 100000 nM
Compound 3: only a limit was reported (the forecaster's own chance of this, stated with the estimate: 85%); the middle value sits exactly at the limit.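

In this assay compound 3 gives > 100000 nM, which is a limit and not a number. The steps joining compound 3 to compound 1 and compound 2 therefore cannot be read: the limit of > 100000 nM in this assay, at which 3 of the 3 values shown sit.

The compounds shown leave open whether any aryl group on the shared core would give a measurable number in this assay.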